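The source may report more compounds than this note shows. Statements on the series, on what has been measured and on what is new or still open speak of the compounds shown alone.

Measured so far in a functional assay on OVCAR-5 cells (Homo sapiens) for inhibition, read by sulforhodamine B assay, with a stated time of 48 h; a lower number here means a stronger inhibitor of growth, a higher number a weaker inhibitor of growth:
- compound 1 `Cc1ccc(NC(=O)/C=C/c2ccccc2)c(C(N)=O)c1`: 8200 nM
- compound 2 `NC(=O)c1cc(Br)ccc1NC(=O)/C=C/c1ccccc1`: 2920 nM

Of these two compounds, compound 2 has the lower number and is therefore the stronger inhibitor of growth. Compound 3 `NC(=O)c1cc(I)ccc1NC(=O)/C=C/c1ccccc1` has not yet been measured. It differs from compound 2 by one group: iodo in place of bromo on an aromatic carbon. Put simply, this is iodo in place of bromo on an aromatic carbon.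

Among the compounds with values here, only one measured step bears on this change: a 2.8-fold lower number from compound 1 to compound 2 (0.45 log units; beyond the scatter). That modest step placed bromo where methyl had been. It involves a different pair of groups, so it is only a weak guide. A small further drop in this assay is expected, possibly no larger than the scatter. The estimated change is a 1.3-fold lower number from compound 2 to compound 3 (0.10 log units; within the scatter). For compound 3, the expected value is 2300 nM, with an estimated range of 1000 nM to 5500 nM.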

Compound 3, concentration for 50% growth inhibition: 3520 nM
Compound 3: middle estimate off by 1.5-fold (0.18 log units), on the low side; the measured number falls inside the stated range.
By their numbers in this assay, from the lowest: compounds 2 and 3 (each within the scatter of the next); then compound 1.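

Placed para to a large group on the shared core, iodo in place of bromo gives a 1.2-fold higher number from compound 2 to compound 3 (0.08 log units; within the scatter) in this assay, so this assay does not separate these two groups at this position. Iodo in place of methyl gives a 2.3-fold lower number from compound 1 to compound 3 (0.37 log units; beyond the scatter) in the same assay, which means that both bromo and iodo now stand apart from methyl across these three compounds. No measurement here explains these numbers or links them to any property of the groups.

Only methyl, bromo and iodo appear at this position in the compounds shown, so it remains open whether chloro or fluoro would fit alongside bromo and iodo. From the compounds shown here alone, what a group of another kind, such as an amine, a methoxy group or a carboxylic acid, would do at this position also stays open.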